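The compounds below may be only part of what the source reports. "The series", "measured", "known", "first", "only" and "open" are said of these compounds alone.

Of the compounds shown here, two from the same series have been tested in an assay on isolated protein (strain Wistar) for inhibition of Voltage-gated L-type calcium channel (Rattus norvegicus); a higher number here means that more compound is needed for the effect, a lower number that less compound is needed. Compound 1 `CCOC1C=C(CC[C@]2(C)[C@@H](C)CC[C@@]3(C)C(C(=O)O)=CC=C[C@@H]23)C(=O)O1` carries an ethoxy group on a saturated ring carbon and gives 14000 nM in this assay. Compound 2 `C=C1CC[C@H](C)[C@@](C)(CCC2=CC(OCC)OC2=O)C/C=C\C=C/1C(=O)O` keeps the same ethoxy group on a different core, and in this assay compound 2 gives 12000 nM. The two numbers lie within the usual scatter of repeated measurements of each other, so compound 2 cannot be told apart from compound 1 on these figures.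

Compound 3 `C=C1CC[C@H](C)[C@@](C)(CCC2=CC(O)OC2=O)C/C=C\C=C/1C(=O)O` has not yet been measured. Compared with compound 2, the change is hydrogen in place of ethyl on an oxygen on a saturated carbon. Among the compounds with values here, no measured pair in this set shows that change, so its effect can only be guessed. Since both known compounds sit at a similar level, the step from compound 2 to compound 3 is expected to be small, most likely a 1.3-fold higher number from compound 2 to compound 3 (0.10 log units; within the scatter), and could fall either way within the scatter. Compound 3 is therefore estimated at 15000 nM, with a likely range from 5000 nM to 45000 nM.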

Compound 3, half-maximal effective concentration: 4100 nM
Estimate against measurement, compound 3: 3.7-fold (0.56 log units) above; measured number outside the range, below it.
By their numbers in this assay, from the lowest: compound 3; then compounds 2 and 1 (each within the scatter of the next).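

Within the data shown here, at the saturated carbon that carries this oxygen, going from ethoxy to hydroxy is the first change in the set that moves the number beyond the usual scatter: in this assay the result is a 2.9-fold lower number from compound 2 to compound 3 (0.47 log units; beyond the scatter) and less compound is needed once the ethyl group is gone. Compound 1 and compound 2 both carry the ethoxy group, so neither could show whether this position responds to what sits on its oxygen; the new pair shows that it does, though the step is modest and rests on this single pair on one core. The data offer no measured explanation for why replacing ethyl with hydrogen lowers the number.

Going by these compounds, it remains open whether a methoxy group or a longer chain such as propoxy would give a number closer to that of the ethoxy compound or the hydroxy compound, and whether an amine in the same place would behave like the hydroxy group. It is also unknown whether the same change from ethoxy to hydroxy on the core of compound 1 would give a step of similar size.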